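The source may hold more compounds than are shown below. What is called first, only, known or untested is meant among the compounds shown, and "the series" means these compounds.

In a functional assay on HL60/MX2 cells (Homo sapiens) for antiproliferative activity, read by MTT assay, with a stated time of 48 h (on this read-out higher numbers stand for weaker inhibition and lower numbers for stronger inhibition), three compounds that share one core have been measured. Compound 1 `CCn1c(N)c(-c2nc3ccccc3[nH]2)c2nc(C#N)c(C#N)nc21` gives > 50000 nM, which is a limit of the assay and not a number. Compound 2 `CN(C)CCn1c(N)c(-c2nc3ccccc3[nH]2)c2nc(C#N)c(C#N)nc21` gives 3780 nM and compound 3 `CN1CCN(CCn2c(N)c(-c3nc4ccccc4[nH]3)c3nc(C#N)c(C#N)nc32)CC1` gives 6490 nM, so these two stand within the scatter of each other.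

Compound 4 `CN(C)CCCn1c(N)c(-c2nc3ccccc3[nH]2)c2nc(C#N)c(C#N)nc21` has not yet been measured. It differs from compound 3 by (dimethylamino)methyl in place of 4-methylpiperazin-1-yl on a saturated chain carbon, two bonds along the chain from an aromatic nitrogen. Read one bond further out, 2-(4-methylpiperazin-1-yl)ethyl becomes 3-(dimethylamino)propyl.

Placing dimethylamino on that chain carbon instead of hydrogen gave an at least 13-fold lower number from compound 1 to compound 2 (1.12 log units; beyond the scatter), a large step. Placing 4-methylpiperazin-1-yl there gave an at least 7.7-fold lower number from compound 1 to compound 3 (0.88 log units; beyond the scatter), an at least modest one. Exchanging these two groups gave a 1.7-fold higher number from compound 2 to compound 3 (0.23 log units; within the scatter), within the scatter. Among the measured compounds shown here, no measured compound carries the 3-(dimethylamino)propyl chain, so this comparison is the closest guide, and no step beyond the scatter is expected in this assay. The estimate means a 1.3-fold lower number from compound 3 to compound 4 (0.11 log units; within the scatter), as an expected step. For compound 4 the expected value is 5000 nM, with an estimated range from 1500 nM to 16000 nM.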

Compound 4, half-maximal inhibitory concentration: 2390 nM
The estimate for compound 4 lay 2.1-fold (0.32 log units) above the measured number, and the stated range covers the measured number.
By their numbers in this assay, from the lowest: compounds 4, 2 and 3 (each within the scatter of the next, the first and the last beyond it). At a limit, above all of these: compound 1.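

In this assay, the change from 2-(4-methylpiperazin-1-yl)ethyl to 3-(dimethylamino)propyl gave a 2.7-fold lower number from compound 3 to compound 4 (0.43 log units; beyond the scatter), the only exchange between amine-bearing chains shown here that lies beyond the scatter. Placing (dimethylamino)methyl in place of dimethylamino gave a 1.6-fold lower number from compound 2 to compound 4 (0.20 log units; within the scatter), so the two dimethylamino chains cannot be told apart in this read-out. Placing (dimethylamino)methyl in place of hydrogen gave an at least 20-fold lower number from compound 1 to compound 4 (1.32 log units; beyond the scatter), a step whose size rests on a limit of the assay and not on a number: the limit of > 50000 nM in this assay, at which 1 of the 4 values shown sits.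

The compounds shown leave open how a 3-(4-methylpiperazin-1-yl)propyl chain would read, so the effect of the longer chain cannot be separated from that of the amine in this exchange. They also leave open how a morpholine, a primary amine or a 4-(dimethylamino)butyl chain would read at this position.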